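From indolylamino to pyrimidinylamino: notes on compound 3

The compounds below may be only part of what the source reports. "The series", "measured", "known", "first", "only" and "open" are said of these compounds alone.

- compound 1 `COC(=O)Cn1c(=O)c(S(=O)(=O)c2ccc(F)cc2F)cc2cnc(Nc3ccc4[nH]ccc4c3)nc21` gives 5000 nM
- compound 2 `Cn1c(=O)c(S(=O)(=O)c2ccc(F)cc2F)cc2cnc(Nc3cccc4[nH]ccc34)nc21` gives 1500 nM

In a functional assay on K562 cells (Homo sapiens) for inhibition, read by trypan blue exclusion, with a stated time of 72 h (a lower number here means a stronger inhibitor, a higher number a weaker inhibitor), compound 2 gives 1500 nM and holds the lower of the two numbers, while compound 1 gives 5000 nM as its nearest neighbour, a gap beyond the usual scatter. Compound 3 `Cn1c(=O)c(S(=O)(=O)c2ccc(F)cc2F)cc2cnc(Nc3ccncn3)nc21` differs from compound 2 in one place, with pyrimidin-4-yl in place of 1H-indol-4-yl on a nitrogen on an aromatic ring as the change: pyrimidin-4-yl in place of 1H-indol-4-yl on a nitrogen on an aromatic ring. Within the data shown here, no measured pair differs in one place, so the data give no direct guide to this step. A moderate step towards a higher number in this assay is expected, meaning weaker inhibition, beyond the scatter. The expected size is a 3.3-fold higher number from compound 2 to compound 3 (0.52 log units; beyond the scatter) on this estimate. For compound 3 the estimated value is 5000 nM with an expected range from 1500 nM to 15000 nM in repeat measurements.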

Compound 3, half-maximal inhibitory concentration: 30000 nM
Compound 3: the middle estimate sits 6.0-fold (0.78 log units) below what was measured; the whole stated range lies below it.
By their numbers in this assay, from the lowest: compound 2; then compound 1; then compound 3.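

In this assay, the group on this nitrogen on an aromatic ring proves far from interchangeable: with the shared core unchanged, the change gives a 20-fold higher number from compound 2 to compound 3 (1.30 log units; beyond the scatter), a large move towards weaker inhibition. The step replaces the two-ring 1H-indol-4-yl, which has a hydrogen-bond donor, with the single-ring pyrimidin-4-yl, which has no donor and two hydrogen-bond acceptors. Ring count, ring nitrogens, donor and acceptors all change together, so this one step cannot separate their contributions, and no supporting evidence bears on the result.

Going by these compounds, whether a plain phenyl group or 1-methylindol-4-yl on the same nitrogen would stay close to compound 2 remains open. Also open, on these data alone, is whether an amine or a longer chain on pyrimidin-4-yl would change the number for compound 3.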